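Notes on amide substituent variation in the series

The source may hold more compounds than are shown below. What is called first, only, known or untested is meant among the compounds shown, and "the series" means these compounds.

Measured compounds:
compound 1 `CC[C@@H](C)[C@H](NC(=O)c1ccc(C(CC)(CC)c2ccc(OCC(=O)C(C)(C)C)c(C)c2)n1CC)C(=O)OC`: 590 nM
compound 2 `CCn1c(C(=O)NCCN)ccc1C(CC)(CC)c1ccc(OCC(=O)C(C)(C)C)c(C)c1`: 120 nM

In an assay on HL-60 cells for agonist activity at vitamin D3 receptor (Homo sapiens), read by microscopy, with a stated time of 96 h (a lower number here means that less compound is needed, a higher number that more compound is needed for the effect), compound 1 gives 590 nM, while compound 2 gives 120 nM, the lowest of the two numbers. For the measured compounds named here, the only measured step is a 4.9-fold lower number from compound 1 to compound 2 (0.69 log units; beyond the scatter), where the smaller amide substituent gave the lower number.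

Compound 3 `CCn1c(C(=O)N(CCC#N)CCC#N)ccc1C(CC)(CC)c1ccc(OCC(=O)C(C)(C)C)c(C)c1` carries a group of 9 heavy atoms (6 carbon, 3 nitrogen; no ring) in place of a group of 4 heavy atoms (2 carbon, 2 nitrogen; no ring), on a carbonyl carbon. This step bears only loosely on the one known; because a 4.9-fold lower number from compound 1 to compound 2 (0.69 log units; beyond the scatter) ran toward the smaller substituent and compound 3 again carries the larger group, a modest rise is expected here. The expected step is a 2.9-fold higher number from compound 2 to compound 3 (0.46 log units; beyond the scatter). Compound 3 is estimated at 350 nM, with a range from 120 nM to 1200 nM.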

Compound 3, half-maximal effective concentration: 870 nM
For compound 3 the middle estimate is 2.5-fold (0.40 log units) below the measured one; measured number inside the range.
By their numbers in this assay, from the lowest: compound 2; then compounds 1 and 3 (each within the scatter of the next).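

On the carbonyl carbon, the group of 9 heavy atoms with its two nitrile chains is a clear loss against (2-aminoethyl)amino in this assay (a 7.3-fold higher number from compound 2 to compound 3 (0.86 log units; beyond the scatter)). It stands level with the branched ester-bearing group of compound 1 (a 1.5-fold higher number from compound 1 to compound 3 (0.17 log units; within the scatter)), so among these three compounds, two quite different larger groups both sit apart from compound 2. No measurement at hand accounts for these steps.

Going by these compounds, whether the terminal amine or the short chain matters remains open. A 3-aminopropyl or 2-hydroxyethyl group on the same nitrogen would separate the two.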